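Swapping a Methoxyphenyl for a Methylphenyl on the Triazole

The source may hold more compounds than are shown below. What is called first, only, known or untested is meant among the compounds shown, and "the series" means these compounds.

Four compounds share one core. In an ADME assay on HEK293 cells (Homo sapiens) for inhibition, read by MTT assay, with a stated time of 48 h, tested at 25 uM (on this read-out higher numbers stand for more inhibition at the one concentration tested (going by the name of the read-out) and lower numbers for less inhibition), compound 1 `COc1ccc(NC(=O)Cn2cc(COc3ccc4c(c3)CCC4)nn2)cc1` gives "not determined" (no result reported) and compound 2 `CCc1ccc(-n2cc(COc3ccc4c(c3)CCC4)nn2)cc1` gives "not determined" (no result reported), so neither has a result reported. Among the measured compounds shown here, compound 3 `COc1ccccc1-n1cc(COc2ccc3c(c2)CCC3)nn1` is the only one with a number: in this assay compound 3 gives 19.8%, a modest level of inhibition. Compound 4 `Cc1cccc(-n2cc(COc3ccc4c(c3)CCC4)nn2)c1` has not yet been tested. The change is 3-methylphenyl in place of 2-methoxyphenyl on an aromatic nitrogen. For the measured compounds named here, no measured pair shows how such a change moves the read-out here, so there is no basis to expect a shift beyond the scatter in either direction. Compound 4 is therefore expected to land near compound 3, with a step of a number 1.8 percentage points lower from compound 3 to compound 4 (within the scatter) that stays inside the usual scatter. The estimate for compound 4 is 18%, within a range from 5% to 35%.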

Compound 4, a percentage reported as inhibition, at one concentration (the size of the read-out at that concentration, not a potency): 23.4%
Beside the measured number, compound 4's estimate is 5.4 percentage points below it, and the stated range covers the measured number.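

In this assay, among the compounds shown here, 3-methylphenyl in place of 2-methoxyphenyl on the aromatic nitrogen gives a number 3.6 percentage points higher from compound 3 to compound 4 (within the scatter), the first comparison of two numbers at this position. The group that enters has no hydrogen-bond acceptor and the group that leaves has one, yet this single pair shows no step beyond the scatter. Nothing available explains this result.

As far as these compounds go, whether an amine or a carboxylic acid on this phenyl ring would shift the read-out remains open. So does whether a longer chain on the aromatic nitrogen would behave like these two groups.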